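Cytotoxicity Estimate After Replacing Benzoyl With Pyrimidin-2-yl

A few compounds are considered here, and "the series" means these few. Any claim that something is new, unique, unknown or untested is made for them only; others in the source may bear on it.

Measured compounds:
compound 1 `CC(=O)c1cc(C(=O)N[C@H](C)Cn2ccc(-c3cc(F)c(C#N)c(Cl)c3)n2)n[nH]1`: "not determined" (no result reported)
compound 2 `C[C@@H](Cn1ccc(-c2ccc(C#N)c(Cl)c2)n1)NC(=O)c1ccccc1`: "not determined" (no result reported)
compound 3 `C[C@@H](Cn1ccc(-c2ccc(C#N)c(Cl)c2)n1)NC(=O)c1cccc(OCC(O)CO)c1`: > 30000 nM

Compound 2 has no result in an ADME assay on L02 cells (Homo sapiens) for cytotoxicity, read by CCK-8 assay, with a stated time of 6 days (a higher number here means a weaker inhibitor, a lower number a stronger inhibitor), so it stands nowhere on the numbers shown. Compound 1 likewise has no result in this assay. Compound 3 reaches only a limit of the assay in this assay, > 30000 nM. The step from compound 2 to compound 4 `C[C@@H](Cn1ccc(-c2ccc(C#N)c(Cl)c2)n1)Nc1ncccn1` changes one spot: pyrimidin-2-yl in place of benzoyl on an amine nitrogen. Within the data shown here, no measured step between any two compounds exists here, so the size of this step in this assay is unknown; the expectation is for no change beyond the usual scatter. Because the limit of > 30000 nM in this assay, at which 1 of the 3 values shown sits, holds for compound 3, compound 4 is expected to also sit near that limit, estimated at 30000 nM, from 10000 nM to 100000 nM.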

Compound 4, half-maximal inhibitory concentration: > 30000 nM
Compound 4: no number, only a limit; the forecaster's own chance of this, stated with the estimate: 70%; the middle value sits exactly at the limit.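

No new step can be read between compound 2 and compound 4, as compound 2 has no number here. In this assay compound 4 gives only a limit, > 30000 nM. The compounds shown leave open whether replacing benzoyl with pyrimidin-2-yl changes cytotoxicity at all.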